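Moving the Chlorine on the Anilino Ring Across Two Cores

This account rests on a few compounds, and the source may have more. Where it says the series, first, only, none or still open, it means among the compounds named here.

Compound 1 `CC(C)c1ccc(-c2nc(SCc3cn(CC(=O)NC(=O)Nc4ccccn4)nn3)nc(Nc3ccc(Cl)cc3)c2C#N)cc1` was tested in a functional assay on ECa-109 cells (Homo sapiens) for inhibition, read by MTT assay, with a stated time of 72 h (on this read-out lower numbers stand for stronger inhibition and higher numbers for weaker inhibition), and gave 11200 nM. Compound 2 `CC(C)c1ccc(-c2nc(SCc3cn(CC(=O)NC(=O)Nc4ccccn4)nn3)nc(Nc3cccc(Cl)c3)c2C#N)cc1` differs from compound 1 only by 3-chlorophenyl in place of 4-chlorophenyl on a nitrogen on an aromatic ring, and in this assay compound 2 gives 13300 nM; that change made a 1.2-fold higher number from compound 1 to compound 2 (0.07 log units; within the scatter). Compound 3 `COc1cc(-c2nc(SCc3cn(CC(=O)NC(=O)Nc4ccccn4)nn3)nc(Nc3ccc(Cl)cc3)c2C#N)cc(OC)c1OC` carries a different core, the difference from compound 1 being (3,4,5-trimethoxyphenyl in place of 4-isopropylphenyl on an aromatic carbon). For compound 3 the read-out in this assay is only a limit of the assay, > 64000 nM. This value stands at the limit of > 64000 nM in this assay, at which 1 of the 3 values shown sits. The change of core made an at least 5.7-fold higher number from compound 1 to compound 3 (0.75 log units; beyond the scatter). Compound 4 `COc1cc(-c2nc(SCc3cn(CC(=O)NC(=O)Nc4ccccn4)nn3)nc(Nc3cccc(Cl)c3)c2C#N)cc(OC)c1OC` has not yet been measured; it stands to compound 3 as compound 2 stands to compound 1, the change being (3-chlorophenyl in place of 4-chlorophenyl on a nitrogen on an aromatic ring), at the same place on the shared core. Since that same change gave a 1.2-fold higher number from compound 1 to compound 2 (0.07 log units; within the scatter) on the first core, it is expected to make a step that the limit leaves unreadable from compound 3 to compound 4 on the second. Compound 4 is therefore estimated at 80000 nM in this assay, with a range from 40000 nM to 200000 nM, and the likeliest outcome is again a limit rather than a number.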

Compound 4, half-maximal inhibitory concentration: > 64000 nM
Compound 4: no number, only a limit; the forecaster's own chance of this, stated with the estimate: 75%; the middle value is on the limit's open side.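

In this assay compound 4 gives > 64000 nM, which is a limit of the assay and not a number. From the compounds shown here alone, compound 3 sits at the same limit, so the step from 4-chlorophenyl to 3-chlorophenyl cannot be read on the core of compound 3, and it remains unknown whether the step within the scatter on the core of compound 1 carries over: the limit of > 64000 nM in this assay, at which 2 of the 4 values shown sit. The step that can be read is the swap of 4-isopropylphenyl for 3,4,5-trimethoxyphenyl, which with 3-chlorophenyl in place made an at least 4.8-fold higher number from compound 2 to compound 4 (0.68 log units; beyond the scatter), so the number rises with either chlorophenyl group, though the sizes of the two steps cannot be compared: the same change on two cores in this assay, an at least 5.7-fold higher number (0.75 log units; beyond the scatter) from compound 1 to compound 3 and an at least 4.8-fold higher number (0.68 log units; beyond the scatter) from compound 2 to compound 4; the limit leaves it open whether they differ.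

The compounds shown leave open whether a group with a single methoxy, or a plain phenyl, in place of 3,4,5-trimethoxyphenyl would bring the values back under the limit. Only such a pair, with both values readable, could show whether moving the chlorine behaves the same way on a second core.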